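A Methyl on an Aromatic Nitrogen: Expected Lipophilicity Shift

The source may report more compounds than this note shows. Statements on the series, on what has been measured and on what is new or still open speak of the compounds shown alone.

Compound 1 `O=C(NCCO)c1ccc2ccc(C(=O)c3ccccc3)c-2cc1`: 2.2
Compound 2 `NC(=O)C1CCN(C(=O)c2c[nH]c3ccccc23)CC1`: -0.2
Compound 3 `COC(=O)c1ccc2c(C(=O)Nc3ccccc3)cn(C)c2c1`: 2.9

Of the compounds shown here, three have been measured in a physicochemical assay for lipophilicity; on this read-out higher numbers stand for higher lipophilicity and lower numbers for lower lipophilicity. Compound 2 stands lowest of the three: compound 1 lies higher, beyond the scatter, and compound 3 lies higher still, also beyond the scatter. Compound 4 `Cn1cc(C(=O)N2CCC(C(N)=O)CC2)c2ccccc21` has not yet been measured in this assay. It differs from compound 2 in one place: methyl in place of hydrogen on an aromatic nitrogen. Within the data shown here, no pair of measured compounds shows this change, so the expectation rests on the change alone. The step is expected to be small and upward, a number 0.40 log units higher from compound 2 to compound 4 (beyond the scatter), at or near the edge of the usual scatter. For compound 4 the estimate in this assay is 0.2, within a range from -0.3 to 0.7.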

Compound 4, partition coefficient: 0.4
The estimate for compound 4 lay 0.20 log units below the measured number, and the stated range covers the measured number.
By their numbers in this assay, from the lowest: compound 2; then compound 4; then compound 1; then compound 3.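

In this assay, among these compounds, methyl in place of hydrogen on an aromatic nitrogen gives a number 0.60 log units higher from compound 2 to compound 4 (beyond the scatter), the first direct reading of this change at this position. The step is modest and rests on this single pair. Nothing available explains its size. From the compounds shown here alone, whether ethyl, a longer chain or a chain ending in an amine on the same nitrogen would move the number further remains open. So does whether methyl gives a similar step on another core.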